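Deoxygenation of the side-chain hydroxyl in a bicyclic lactone series

This account rests on a few compounds, and the source may have more. Where it says the series, first, only, none or still open, it means among the compounds named here.

Measured compounds:
compound 1 `O=C1C[C@H]2O[C@H]([C@H](O)c3ccccc3)[C@H](O)[C@H]2O1`: 18500 nM
compound 2 `O=C(/C=C/c1ccccc1)O[C@H](c1ccccc1)[C@H]1O[C@@H]2CC(=O)O[C@@H]2[C@H]1O`: 15500 nM
compound 3 `O=C1C[C@H]2O[C@H]([C@H](OC(=O)c3ccccc3)c3ccccc3)[C@H](O)[C@H]2O1`: 1010 nM

In a functional assay on Raji cells (Homo sapiens) for antiproliferative activity, read by MTT assay, with a stated time of 72 h (a higher number here means a weaker inhibitor, a lower number a stronger inhibitor), compound 1 gives 18500 nM, the highest number of the three. Its value and that of compound 2 lie within the scatter of each other, so no order between them can be read. Compound 3 stands well apart: the step of an 18-fold lower number from compound 1 to compound 3 (1.26 log units; beyond the scatter) and the step of a 15-fold lower number from compound 2 to compound 3 (1.19 log units; beyond the scatter) are both large and beyond the scatter.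

Compound 4 `O=C1C[C@H]2O[C@H](Cc3ccccc3)[C@H](O)[C@H]2O1` differs from compound 1 in one place: hydrogen in place of hydroxy on a saturated chain carbon bound to an aromatic carbon and a saturated ring carbon. Among the compounds with values here, no measured step removes this hydroxy outright; the only change at this position, in compound 3, is its acylation, which gave the large step of an 18-fold lower number from compound 1 to compound 3 (1.26 log units; beyond the scatter). Removal of the group is not the same change, and nothing in the set shows what loss of the hydroxy alone does. A modest step in this assay is therefore expected, if any, with a lean towards a lower number, but one that may stay within the scatter.

Compound 4 is expected to give 12000 nM, with a range of 4000 nM to 40000 nM, meaning the expected step of a 1.5-fold lower number from compound 1 to compound 4 (0.19 log units; within the scatter).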

Compound 4, half-maximal inhibitory concentration: 1030 nM
Compound 4: middle estimate off by 12-fold (1.07 log units), on the high side; measured number outside the range, below it.
By their numbers in this assay, from the lowest: compounds 3 and 4 (each within the scatter of the next); then compounds 2 and 1 (each within the scatter of the next).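

In this assay, within the data shown here, the free hydroxy on this saturated chain carbon is not needed for activity: its replacement by hydrogen gives an 18-fold lower number from compound 1 to compound 4 (1.25 log units; beyond the scatter), a large step of the kind previously seen only on acylation, in an 18-fold lower number from compound 1 to compound 3 (1.26 log units; beyond the scatter). The benzoyl group is therefore not the only route to this level, since compound 3 at 1010 nM and compound 4 at 1030 nM lie within the scatter of each other, but loss of the free hydroxy is not enough in itself: compound 2 goes against that pattern, remaining at 15500 nM, within the scatter of compound 1. No available evidence bears on the origin of this step.

On these data alone, whether an amine, a methoxy group or a fluorine at this carbon would behave like hydrogen remains open. So does the effect of a longer chain between the core and the phenyl ring.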